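From acetoxy to (propylcarbonyl)oxy on compound 2

The source may report more compounds than this note shows. Statements on the series, on what has been measured and on what is new or still open speak of the compounds shown alone.

Measured so far in a functional assay on MCF7 cells (Homo sapiens) for antiproliferative activity, read by MTT assay, with a stated time of 48 h; a higher number here means a weaker inhibitor, a lower number a stronger inhibitor
- Compound 1 (`CCN(CC)C/C1=C/C[C@](C)(CCC=C(C)C)/C=C/[C@@H](OC(=O)C=C(C)C)[C@](C)(O)/C=C/C1=O`) gives 130 nM
- Compound 2 (`CC(=O)O[C@@H]1/C=C/[C@@](C)(CCC=C(C)C)C/C=C(/CO)C(=O)/C=C/[C@@]1(C)O`) gives 7890 nM

Compound 2 has the higher of the two numbers, so it is the weaker inhibitor, and its gap to compound 1 lies beyond the scatter. Compound 3 (`CCCC(=O)O[C@@H]1/C=C/[C@@](C)(CCC=C(C)C)C/C=C(/CO)C(=O)/C=C/[C@@]1(C)O`) changes acetoxy to (propylcarbonyl)oxy, which is ethyl in place of hydrogen on a saturated chain carbon bound to a carbonyl carbon. Going by the values given here, no measured pair shows this change, so the estimated step (a 1.2-fold lower number from compound 2 to compound 3 (0.08 log units; within the scatter)) is expected to stay within the scatter. Compound 3 is expected at (6500 nM), with a likely range of (2500 nM to 16000 nM).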

Compound 3, half-maximal inhibitory concentration: 6040 nM
The estimate for compound 3 lay 1.1-fold (0.03 log units) above the measured number; low and high end bracket the measured number.
By their numbers in this assay, from the lowest: compound 1; then compounds 3 and 2 (each within the scatter of the next).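

In this assay the result reads a 1.3-fold lower number from compound 2 to compound 3 (0.12 log units; within the scatter) and so adding ethyl on this saturated chain carbon bound to a carbonyl carbon leaves compound 2 and compound 3 indistinguishable. Going by these compounds alone, this is the first single-place comparison here, and it shows that acetoxy and (propylcarbonyl)oxy cannot be told apart at this position. No measured evidence here bears on this result. The compounds shown leave open whether a much longer chain, a phenyl ring or an amine at this place would keep the number within the scatter or move it beyond.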